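Adding an Amino Group on Two Nucleoside Cores

The source may report more compounds than this note shows. Statements on the series, on what has been measured and on what is new or still open speak of the compounds shown alone.

Compound 1 `COc1ncnc2c1c(-c1cccs1)cn2[C@@H]1O[C@H](CO)[C@@H](O)[C@H]1O` and compound 2 `COc1nc(N)nc2c1c(-c1cccs1)cn2[C@@H]1O[C@H](CO)[C@@H](O)[C@H]1O` share one core, while compound 3 `O=c1[nH]cnc2c1c(-c1ccco1)cn2[C@@H]1O[C@H](CO)[C@@H](O)[C@H]1O` and compound 4 `Nc1nc2c(c(-c3ccco3)cn2[C@@H]2O[C@H](CO)[C@@H](O)[C@H]2O)c(=O)[nH]1` share another; the difference between the two cores is not broken down here. In an ADME assay on MRC5 cells (Homo sapiens), read by MTT assay, with a stated time of 72 h (on this read-out higher numbers stand for weaker inhibition and lower numbers for stronger inhibition), compound 1 gives 43200 nM. For compound 2 this assay reports only a limit, > 100000 nM. The step of an at least 2.3-fold higher number from compound 1 to compound 2 (0.36 log units; beyond the scatter) comes from amino in place of hydrogen on an aromatic carbon. For compound 3 this assay also reports only a limit, > 100000 nM. Compound 4 differs from compound 3 by amino in place of hydrogen on an aromatic carbon, the same kind of change, the place differing only in being meta to a group of 1 heavy atom rather than meta to a methoxy group. Compound 3 already sits at the limit of > 100000 nM in this assay, at which 2 of the 3 values shown sit, and the earlier step of an at least 2.3-fold higher number from compound 1 to compound 2 (0.36 log units; beyond the scatter) raised the number. Compound 4 is therefore expected to give 150000 nM. The step this estimate means is a step that the limit leaves unreadable from compound 3 to compound 4, expected to stay at the limit.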

Compound 4, half-maximal inhibitory concentration: > 100000 nM
Compound 4 gave a limit, no number; the forecaster's own chance of this, stated with the estimate: 85%; the middle value does not contradict the limit.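

No step can be read from compound 3 to compound 4, since both give only a limit in this assay: the limit of > 100000 nM in this assay, at which 3 of the 4 values shown sit.

The compounds shown leave open whether amino in place of hydrogen changes the number at all on the core of compound 3.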